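Swapping the aromatic group on compound 2

The source may report more compounds than this note shows. Statements on the series, on what has been measured and on what is new or still open speak of the compounds shown alone.

In a physicochemical assay for solubility, read by nephelometry, in phosphate buffer, measured as kinetic solubility, at pH 6.5 (a higher number here means a more soluble compound, a lower number a less soluble compound), compound 1 `CCOC(=O)C1=C(C)N/C(=C/c2cc(C)n(-c3ccc(Br)cc3)c2C)C1=O` gives 2.1 ug/mL as a measured number. Compound 2 `CCOC(=O)C1=C(C)N/C(=C/c2cc(C)n(-c3ccc(N(C)C)cc3)c2C)C1=O` gives < 1.6 ug/mL which is a limit of the assay and not a number. Compound 3 `CCOC(=O)C1=C(C)N/C(=C/c2cc(C)n(-c3cccc(OC)c3)c2C)C1=O` is not yet measured; its difference 3-methoxyphenyl in place of 4-(dimethylamino)phenyl on an aromatic nitrogen from compound 2 is 3-methoxyphenyl in place of 4-(dimethylamino)phenyl on an aromatic nitrogen. For the measured compounds named here, the only measured step of an at least 1.3-fold lower number from compound 1 to compound 2 (0.11 log units; that floor lies within the scatter) changed a group on that phenyl ring and stayed within the scatter, so no move beyond the scatter is expected in this assay for this swap. The expected step of an at least 1.3-fold higher number from compound 2 to compound 3 (0.13 log units; that floor lies within the scatter) stays within that scatter. Compound 3 is estimated at 2.2 ug/mL with an expected range from 1.3 ug/mL to 5 ug/mL on repeat measurement.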

Compound 3, solubility: < 1.6 ug/mL
Compound 3 ended at the assay's limit; the forecaster's own chance of this, stated with the estimate: 35%; at least 1.3-fold (0.13 log units) between middle value and limit.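

Exchanging the whole group on the aromatic nitrogen, and not only a group on its phenyl ring, still gives no readable rise: in this assay compound 3 sits at a limit of the assay and not at a number. The swap from 4-bromophenyl gives an at least 1.3-fold lower number from compound 1 to compound 3 (0.11 log units; that floor lies within the scatter) and so shows no move beyond the scatter. The step between the two limits cannot be read, and they share one floor: the limit of < 1.6 ug/mL in this assay, at which 2 of the 3 values shown sit.

From the compounds shown here alone, how far compound 2 and compound 3 lie under that limit stays open. So does whether a carboxylic acid or a morpholine on this phenyl ring would give a number clear of it.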